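The compounds below may be only part of what the source reports. "The series", "measured", "known", "first", "only" and "open" are said of these compounds alone.

Compound 1 `CC1=CC[C@H](C(C)(C)NC(=S)N/N=C/c2ccc(O)cc2)CC1` and compound 2 `CC1=CC[C@H](C(C)(C)NC(=S)N/N=C/c2ccccc2O)CC1` share one core and differ at the carbon with a double bond to nitrogen. In a functional assay on UACC-62 cells (Homo sapiens) for inhibition, read by sulforhodamine B assay, with a stated time of 48 h (on this read-out higher numbers stand for weaker inhibition of growth and lower numbers for stronger inhibition of growth), compound 1 gives > 100000 nM, which is a limit of the assay and not a number. Compound 2 gives 2800 nM in this assay, the only number shown, reached by an at least 35-fold lower number from compound 1 to compound 2 (1.55 log units; beyond the scatter). On these data alone, compound 3 `CC1=CC[C@H](C(C)(C)NC(=S)N/N=C/c2ccc(F)cc2)CC1` is untested; its change is 4-fluorophenyl in place of 2-hydroxyphenyl on a carbon with a double bond to nitrogen. Within the data shown here, the single measured step, between two hydroxyphenyl groups at the same place, was large, so a weakening beyond the scatter in this assay is expected for compound 3, as a 7.1-fold higher number from compound 2 to compound 3 (0.85 log units; beyond the scatter). Compound 3 is therefore estimated at 20000 nM, between 4000 nM and 100000 nM.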

Compound 3, concentration for 50% growth inhibition: > 100000 nM
Compound 3 ended at the assay's limit (the forecaster's own chance of this, stated with the estimate: 35%); middle value at least 5.0-fold (0.69 log units) from the limit.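

In this assay, 4-fluorophenyl in place of 2-hydroxyphenyl gives an at least 35-fold higher number from compound 2 to compound 3 (1.55 log units; beyond the scatter), so the activity of compound 2 is lost again at this carbon with a double bond to nitrogen. Of the three groups shown here, only 2-hydroxyphenyl gives a readable number, and compound 3 joins compound 1 at a limit of the assay, which is not a number. The step between compound 1 and compound 3 cannot be read: the limit of > 100000 nM in this assay, at which 2 of the 3 values shown sit.

This change alters both the substituent and its place on the ring, so the two effects stay unseparated. On these data alone, whether an amine or a methoxy group in place of that hydroxy would keep the growth inhibition remains open.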